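Does One Stereocentre Change a Cytotoxicity Reading?

This account rests on a few compounds, and the source may have more. Where it says the series, first, only, none or still open, it means among the compounds named here.

Measured in a toxicity assay (Homo sapiens) for cytotoxicity; on this read-out higher numbers stand for an effect only at larger amounts of compound and lower numbers for an effect already at smaller amounts
Compound 1 `Nc1nc(Cl)c2ncn([C@@H]3O[C@H](CO)C=C3F)c2n1` gives 77400 nM; 98800 nM (2 entries)
Compound 2 `Nc1ncnc2c1ncn2[C@@H]1O[C@H](CO)C=C1F` gives > 100000 nM (a limit, not a number)
Compound 3 `OC[C@@H]1C=C(F)[C@H](n2cnc3c(O)ncnc32)O1` gives 92700 nM

Among the measured compounds shown here, compound 3 holds the only single number among the three. Compound 1 has two entries, as the several entries of compound 1 in this assay, 77400 nM; 98800 nM (2 entries) shows. Compound 2 reports only a limit, as the limit of > 100000 nM in this assay, at which 1 of the 3 values shown sits, shows.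

The next compound, compound 4 `OC[C@@H]1C=C(F)[C@@H](n2cnc3c(O)ncnc32)O1`, has not yet been measured. It differs from compound 3 in one way: the two compounds have the same atoms and bonds and differ only in configuration as drawn: 1 of 2 stereo elements differ; a stereocentre at a saturated ring carbon is drawn R in compound 3 and S in compound 4. Nothing is added or removed, so the question is whether configuration alone moves the reading.

For the measured compounds named here, no measured step changes configuration, so no direct evidence bears on this. The nearest guide is a step in a different place, hydroxy in place of amino on an aromatic carbon, which is an at least 1.0-fold lower number from compound 2 to compound 3 (0.03 log units; that floor lies within the scatter). That step gives no sign of a shift, but it can only hint at what a stereocentre might do. The two entries of compound 1 also sit in the same high region as compound 3 at 92700 nM.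

No change beyond the scatter is therefore expected in this assay, and a limit reading would be no surprise. The expected step is a 1.0-fold higher number from compound 3 to compound 4 (0.01 log units; within the scatter). Compound 4 is estimated at 95000 nM, with an expected range from 55000 nM to 150000 nM.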

Compound 4, half-maximal effective concentration: > 100000 nM
Compound 4: no number, only a limit (the forecaster's own chance of this, stated with the estimate: 45%); middle value at least 1.0-fold (0.02 log units) away from the limit.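

In this assay, among the compounds shown here, the change of drawn configuration at this saturated ring carbon gives an at least 1.0-fold higher number from compound 3 to compound 4 (0.03 log units; that floor lies within the scatter) and so adds the first reading on this stereocentre, since the only earlier step changed a group on an aromatic carbon. Compound 4 gives > 100000 nM as its reading, which is a limit and not a number. The step therefore has only a floor, and with that floor inside the scatter, a real shift from this one change of configuration is neither shown nor ruled out, while the series stays at the high end of the read-out, with limits now as common as single readings: (the limit of > 100000 nM in this assay, at which 2 of the 4 values shown sit).

The compounds shown leave open how far compound 4 really lies from compound 3, since a limit gives no exact position to compare. They also leave open whether this stereocentre would matter with another group on the aromatic carbon, such as a methoxy group or a thiol in place of hydroxy, and what the second stereo element would do if it were changed instead.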